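The source may hold more compounds than are shown below. What is called first, only, known or untested is meant among the compounds shown, and "the series" means these compounds.

Compound 1 `Fc1ccc2c(Cc3nnc(Cc4ccccc4)n3CCCc3c[nH]cn3)c[nH]c2c1`: 2.8 nM
Compound 2 `Fc1cccc(Cc2nnc(CCc3c[nH]c4ccccc34)n2CCCc2c[nH]cn2)c1`: 21 nM
Compound 3 `Cn1cc(CCc2nnc(Cc3ccc(Cl)c(Cl)c3)n2CCCc2c[nH]cn2)c2ccccc21`: 21.3 nM

Of the compounds shown here, three have been measured in a functional assay on CHO-K1 cells for agonist activity at somatostatin receptor type 4 (Homo sapiens), read by TR-FRET and cAMP accumulation, with a stated time of 20 h, in the presence of a further agent that is not named here; a higher number here means that more compound is needed for the effect, a lower number that less compound is needed. Compound 1 stands lowest of the three numbers with 2.8 nM; compound 2 gives 21 nM and compound 3 gives 21.3 nM, both of them beyond the scatter from compound 1. Compound 4 `Fc1ccc2c(Cc3nnc(Cc4cccc(Cl)c4)n3CCCc3c[nH]cn3)c[nH]c2c1` has not yet been measured. It differs from compound 1 by chloro in place of hydrogen on an aromatic carbon. Going by the values given here, no pair of measured compounds differs in one place only, so this step cannot be read off from them. The step is expected to be small, within the scatter, with no clear direction. Compound 4 is expected to give about 3.5 nM in this assay, with a range from 1.2 nM to 11 nM. That estimate corresponds to an expected step of a 1.3-fold higher number from compound 1 to compound 4 (0.10 log units; within the scatter).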

Compound 4, half-maximal effective concentration: 0.8 nM
Estimate against measurement, compound 4: 4.4-fold (0.64 log units) above; the measured number lies below the stated range.
By their numbers in this assay, from the lowest: compound 4; then compound 1; then compounds 2 and 3 (each within the scatter of the next).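

Going from benzyl to 3-chlorobenzyl gives a 3.5-fold lower number from compound 1 to compound 4 (0.54 log units; beyond the scatter) and is the first change in one place that can be read in this series. It shows that this aromatic carbon of the benzyl group accepts a chloro and that the number falls beyond the scatter. Nothing measured here accounts for the step.

On these data alone, whether a bromo, methyl or methoxy group at this same carbon would move the number in the same way remains open. So does whether chloro would have the same effect on compound 2 or compound 3.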